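Compound 4: an (isoquinolin-4-yl)oxy analogue of compound 2

A few compounds are considered here, and "the series" means these few. Any claim that something is new, unique, unknown or untested is made for them only; others in the source may bear on it.

Compound 1 `CC(C)[C@H](NC(=O)COc1cccc2ccccc12)C(=O)N[C@@H](CC(=O)O)C(=O)CSC1=NCCS1`: in a functional assay on Jurkat cells (Homo sapiens) for inhibition (a lower number here means a stronger inhibitor, a higher number a weaker inhibitor), compound 1 gives > 200000 nM, which is a limit of the assay and not a number.
Compound 2 `Cc1nnc(SCC(=O)[C@H](CC(=O)O)NC(=O)[C@@H](NC(=O)COc2cccc3ccccc23)C(C)C)s1`: in this assay compound 2 gives 190000 nM.
Compound 3 `CC(C)[C@H](NC(=O)COc1cccc2ccccc12)C(=O)N[C@@H](CC(=O)O)C(=O)COc1cc(C(F)(F)F)ncn1`: in this assay compound 3 gives > 200000 nM, which is a limit of the assay and not a number.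

Among the compounds with values here, compound 2 holds the only number in the set; the other two results are the limit of > 200000 nM in this assay, at which 2 of the 3 values shown sit. The steps among the three compounds are all flat: an at least 1.0-fold lower number from compound 1 to compound 2 (0.02 log units; that floor lies within the scatter), an at least 1.0-fold higher number from compound 2 to compound 3 (0.02 log units; that floor lies within the scatter), and a step that the two limits leave unreadable from compound 1 to compound 3.

Compound 4 `CC(C)[C@H](NC(=O)COc1cccc2ccccc12)C(=O)N[C@@H](CC(=O)O)C(=O)COc1cncc2ccccc12` differs from compound 2 in one place: (isoquinolin-4-yl)oxy in place of (5-methyl-1,3,4-thiadiazol-2-yl)sulfanyl on a saturated chain carbon bound to a carbonyl carbon. Within the data shown here, the closest precedent is the step from compound 2 to compound 3, where another group entered at the same place and the result was an at least 1.0-fold higher number from compound 2 to compound 3 (0.02 log units; that floor lies within the scatter). Among the measured compounds shown here, nothing among the measured compounds shows that a change at this position moves the number beyond the scatter, so for compound 4 no step beyond the scatter is expected in this assay, and it is estimated that a 1.1-fold higher number from compound 2 to compound 4 (0.02 log units; within the scatter). Compound 4 is therefore expected to give 200000 nM in this assay, within a range from 100000 nM to 400000 nM, with a real chance that only a limit is reported.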

Compound 4, half-maximal inhibitory concentration: 166000 nM
The estimate for compound 4 lay 1.2-fold (0.08 log units) above the measured number, and the stated range covers the measured number.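

In this assay, the exchange of (5-methyl-1,3,4-thiadiazol-2-yl)sulfanyl for (isoquinolin-4-yl)oxy on a saturated chain carbon bound to a carbonyl carbon gives a 1.1-fold lower number from compound 2 to compound 4 (0.06 log units; within the scatter). This adds a second measured number at this place, and it shows that (isoquinolin-4-yl)oxy leaves the result within the scatter of the (5-methyl-1,3,4-thiadiazol-2-yl)sulfanyl group it replaces. The comparisons with the two remaining compounds are only floors, an at least 1.2-fold lower number from compound 3 to compound 4 (0.08 log units; that floor lies within the scatter) and an at least 1.2-fold lower number from compound 1 to compound 4 (0.08 log units; that floor lies within the scatter), so neither separates compound 4 from them.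

As far as these compounds go, the set therefore shows no change at this place that moves the number beyond the scatter, and some of its results are not numbers at all: the limit of > 200000 nM in this assay, at which 2 of the 4 values shown sit. Still open is whether (isoquinolin-4-yl)sulfanyl, an amine on the isoquinoline ring or a longer chain at this place would move the number, since the step from compound 2 to compound 4 changes the ring and the linking atom together.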